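A few compounds are considered here, and "the series" means these few. Any claim that something is new, unique, unknown or untested is made for them only; others in the source may bear on it.

Measured so far:
compound 1 `O=C(COc1cccc2ccccc12)N/N=C/c1ccc([N+](=O)[O-])cc1`, 3.97 in a physicochemical assay for lipophilicity, measured as octanol-water partition; on this read-out higher numbers stand for higher lipophilicity and lower numbers for lower lipophilicity
compound 2 `O=C(COc1cccc2ccccc12)N/N=C/c1c[nH]c2ccccc12`, 3.79

In this assay compound 1 gives the higher of the two numbers, but its gap to compound 2 lies within the scatter, so no order between them can be read. Compound 3 `COc1ccc(/C=N/NC(=O)COc2cccc3ccccc23)cc1` is not yet measured. It differs from compound 1 in one place: methoxy in place of nitro on an aromatic carbon. Among the measured compounds shown here, nothing among the measured pair shows what this exchange does here. The step from compound 1 to compound 3 is expected to be small and upward, a number 0.23 log units higher from compound 1 to compound 3 (within the scatter), at the edge of the scatter. Compound 3 is estimated at 4.2, within 3.8 to 4.6.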

Compound 3, partition coefficient: 3.77
For compound 3 the middle estimate is 0.43 log units above the measured one; the whole stated range lies above it.
By their numbers in this assay, from the lowest: compounds 3, 2 and 1 (each within the scatter of the next).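

In this assay, methoxy in place of nitro on the aromatic carbon para to a large group gives a number 0.20 log units lower from compound 1 to compound 3 (within the scatter). This position therefore now has a direct comparison, and on this read-out the two groups cannot be told apart. No measured information bears on the reason for this result.

On these data alone, whether an amine or a carboxylic acid on this same carbon would give a step beyond the scatter remains open. Also open, as far as these compounds go, is whether the exchange of nitro for methoxy gives a similar step elsewhere on the shared core.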